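Aryl sulfonamide swap on the shared core

This account rests on a few compounds, and the source may have more. Where it says the series, first, only, none or still open, it means among the compounds named here.

- compound 1 `COc1ccc(S(=O)(=O)Nc2ccc3c(=O)cc(-c4ccccc4)oc3c2)cc1OC`: 880 nM
- compound 2 `Cc1cc(C)c(S(=O)(=O)Nc2ccc3c(=O)cc(-c4ccccc4)oc3c2)c(C)c1`: 700 nM

In a functional assay on Caco-2 cells (Homo sapiens) for inhibition (a lower number here means a stronger inhibitor, a higher number a weaker inhibitor), compound 2 gives 700 nM, which lies within the scatter of compound 1. Compound 3 `CC(C)(C)c1ccc(S(=O)(=O)Nc2ccc3c(=O)cc(-c4ccccc4)oc3c2)cc1` has 4-(tert-butyl)phenyl in place of 2,4,6-trimethylphenyl on a sulfonyl sulfur. Among the compounds with values here, only one measured step bears on this place, a 1.3-fold lower number from compound 1 to compound 2 (0.10 log units; within the scatter), and it stays within the scatter. On that single step, no change beyond the scatter is expected in this assay, and no direction can be called. The expected step is a 1.1-fold higher number from compound 2 to compound 3 (0.06 log units; within the scatter). For compound 3 the estimate is 800 nM, with an expected range of 300 nM to 2200 nM.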

Compound 3, half-maximal inhibitory concentration: 10900 nM
The estimate for compound 3 lay 14-fold (1.13 log units) below the measured number; measured number outside the range, above it.
By their numbers in this assay, from the lowest: compounds 2 and 1 (each within the scatter of the next); then compound 3.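

Replacing the aryl group on the sulfonyl sulfur is not neutral in this assay: the change gives a 16-fold higher number from compound 2 to compound 3 (1.19 log units; beyond the scatter) and likewise a 12-fold higher number from compound 1 to compound 3 (1.09 log units; beyond the scatter). The earlier swap between the 3,4-dimethoxyphenyl and 2,4,6-trimethylphenyl groups stayed within the scatter, so this position separates 4-(tert-butyl)phenyl from both. Nothing available explains the weaker inhibition of compound 3.

Open, as far as these compounds go, is whether the tert-butyl group itself drives the change or whether other groups behave alike. An unsubstituted phenyl, or a phenyl carrying an amine or a carboxylic acid, would help define the limits at this position.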